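From 4-cyanophenyl to 3-cyanophenyl: working notes

The source may hold more compounds than are shown below. What is called first, only, known or untested is meant among the compounds shown, and "the series" means these compounds.

Of the compounds shown here, three have been measured so far. In a functional assay on SK-N-SH cells (Homo sapiens) for inhibition, read by MTT assay, with a stated time of 72 h, tested at 50 uM (on this read-out higher numbers stand for more inhibition of growth at the one concentration tested and lower numbers for less inhibition of growth), compound 2 (`C=CCc1ccc(OCc2cn(-c3ccc(C#N)cc3)nn2)c(O)c1`) gives 62.5%, the top number of the three, although that lead is not secure. Compound 3 (`C=CCc1ccc(OCc2cn(-c3cc(OC)c(OC)c(OC)c3)nn2)c(O)c1`) gives 55.9%, which lies within the scatter of compound 2. Compound 1 (`C=CCc1cc(O)c(O)c(CN2CCC(CCO)CC2)c1`) gives 40.6%, lower than compound 2 by a gap beyond the scatter.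

The next compound to be tested is compound 4 (`C=CCc1ccc(OCc2cn(-c3cccc(C#N)c3)nn2)c(O)c1`). It has the same atoms as compound 2, joined differently: 3-cyanophenyl in place of 4-cyanophenyl on an aromatic nitrogen of a five-membered aromatic ring with 3 nitrogen. 3-cyanophenyl in place of 4-cyanophenyl on an aromatic nitrogen

Among the compounds with values here, no measured pair differs in one place only, so the size of this step has no direct precedent. The nearest guide is compound 3, which carries a different group on that aromatic nitrogen and still gives 55.9%, within the scatter of compound 2. On that basis, a small drop is expected, with the estimated step of a number 4.5 percentage points lower from compound 2 to compound 4 (within the scatter) staying within the scatter. For compound 4 the expected value in this assay is 58%, with an estimated range from 44% to 72%.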

Compound 4, percent growth inhibition at one concentration: 78.8%
For compound 4 the middle estimate is 20.8 percentage points below the measured one; measured number outside the range, above it.
By their numbers in this assay, from the lowest: compound 1; then compounds 3 and 2 (each within the scatter of the next); then compound 4.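

Within the data shown here, the change of 3-cyanophenyl in place of 4-cyanophenyl on an aromatic nitrogen gives, in this assay, a number 16.3 percentage points higher from compound 2 to compound 4 (beyond the scatter), and this is the first step that can be read at a single place. Among these compounds, the two compounds have the same atoms and the same counts of donors and acceptors, so the point of attachment of the nitrile on the phenyl ring is by itself enough to shift the read-out beyond the scatter, something the earlier compounds, which differ in more than one place, could not show. Nothing available bears on why the 3-cyanophenyl compound reads higher than the 4-cyanophenyl compound.

Going by these compounds, it remains open whether 2-cyanophenyl on the same nitrogen would continue this trend, and whether the higher reading depends on the nitrile itself or would carry over to a carboxylic acid or an aminomethyl group at the same place on the phenyl ring. Since the read-out comes from one concentration in one cell line, the compounds shown also leave open how this step would look across a range of concentrations or in other cells.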